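The source may hold more compounds than are shown below. What is called first, only, known or untested is meant among the compounds shown, and "the series" means these compounds.

Measured compounds:
compound 1, `CC1(C)C=C(n2ccccc2=O)c2ccccc2O1`, 5.43
compound 2, `COc1ccc2c(c1)C(n1ccccc1=O)=CC(C)(C)O2`, 6.55
compound 3, `CC(=O)Oc1ccc2c(c1)C(n1ccccc1=O)=CC(C)(C)O2`, 5.6

Compound 1 stands lowest of the three numbers in a functional assay (aorta) with Rattus norvegicus as the target; a lower number here means a less potent compound, a higher number a more potent compound, by a factor of ten per unit of this negative logarithm. Its nearest neighbour is compound 3, with a number 0.17 log units higher from compound 1 to compound 3 (within the scatter); the furthest is compound 2, with a number 1.12 log units higher from compound 1 to compound 2 (beyond the scatter). Between the two substituted analogues, a number 0.95 log units lower from compound 2 to compound 3 (beyond the scatter).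

Compound 4, `CC1(C)C=C(n2ccccc2=O)c2cc(C(F)(F)F)ccc2O1`, is not yet measured. It differs from compound 1 by trifluoromethyl in place of hydrogen on an aromatic carbon. For the measured compounds named here, the steps that bear on it are the two other substitutions at the same aromatic carbon of the shared core: methoxy gave a large rise, a number 1.12 log units higher from compound 1 to compound 2 (beyond the scatter), whereas acetoxy gave only a number 0.17 log units higher from compound 1 to compound 3 (within the scatter). Going by the values given here, no step introduces trifluoromethyl, so the size of the change cannot be read from a direct analogue; what is known is that substitution at this carbon has ranged from no change beyond the scatter to a large gain. A modest rise is therefore expected, with a wide range to cover both outcomes. The step from compound 1 is estimated at a number 0.37 log units higher from compound 1 to compound 4 (beyond the scatter). Compound 4 is expected to give 5.8 in this assay, in the range 5.2 to 6.5.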

Compound 4, logarithm of the reciprocal of the active concentration, log(1/C): 7.61
The estimate for compound 4 lay 1.81 log units below the measured number, outside the stated range (above it).
By their numbers in this assay, from the lowest: compounds 1 and 3 (each within the scatter of the next); then compound 2; then compound 4.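

In this assay, trifluoromethyl on this aromatic carbon, meta to a fused ring and para to a fused ring, gives a number 2.18 log units higher from compound 1 to compound 4 (beyond the scatter), so the substituents seen earlier did not mark the upper end of what a change at this carbon can give. The replacement of one group by another at the same carbon separates the three substituents clearly, with a number 1.06 log units higher from compound 2 to compound 4 (beyond the scatter) and a number 2.01 log units higher from compound 3 to compound 4 (beyond the scatter), which places compound 4 beyond the scatter of every other compound in the series and makes it the most potent of the four. No measured property accompanies these compounds, so nothing shown accounts for the order of the substituents at this carbon.

As far as these compounds go, whether a nitrile, an amine or a carboxylic acid at this carbon would fall nearer compound 4 or nearer compound 1 remains open. Also open is whether trifluoromethyl would give a step of this size on another aromatic carbon of the shared core, since all the substituted compounds shown carry their group at this one carbon.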